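From Propyl to Butyl on a Shared Core

The source may hold more compounds than are shown below. What is called first, only, known or untested is meant among the compounds shown, and "the series" means these compounds.

Of the compounds shown here, three sharing one core have been measured. In a functional assay with Alpha-1B adrenergic receptor (Homo sapiens) as the target, read by calcium flux (on this read-out lower numbers stand for smaller maximal responses and higher numbers for larger maximal responses), compound 1 `CCCn1ncnc1-c1ccccc1NCC1=NCCN1` gives 74%, compound 2 `c1ccc(-c2nc[nH]n2)c(NCC2=NCCN2)c1` gives 100%, and compound 3 `c1ccc(-c2cn[nH]c2)c(NCC2=NCCN2)c1` gives 72%. Compound 1 thus stands below compound 2 by a gap beyond the usual scatter, and alongside compound 3, from which it differs by less than the scatter. Among the measured compounds shown here, the one change measured within this set, 1H-pyrazol-4-yl in place of 1H-1,2,4-triazol-3-yl on an aromatic carbon, gave a number 28 percentage points lower from compound 2 to compound 3 (beyond the scatter).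

Compound 4 `CCCCn1ncnc1-c1ccccc1NCC1=NCCN1` has not yet been measured. It differs from compound 1 by methyl in place of hydrogen on a saturated chain carbon, three bonds along the chain from an aromatic nitrogen. For the measured compounds named here, no measured step touches this kind of change: the only step measured swaps one ring for another, and nothing in the data alters the saturated chain. With no guidance from the measured pairs, the expectation is no step beyond the scatter, and compound 4 is therefore estimated at 74%, within 55% to 92%. The step expected is no change at the digits printed from compound 1 to compound 4 (within the scatter) in this assay.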

Compound 4, largest response reached (reported as maximal response), in percent of the reference or control that the assay uses: 83%
Compound 4: middle estimate off by 9 percentage points, on the low side, and the stated range covers the measured number.
By their numbers in this assay, from the lowest: compounds 3, 1 and 4 (each within the scatter of the next, the first and the last beyond it); then compound 2.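

Going from propyl to butyl on the saturated chain gives a number 9 percentage points higher from compound 1 to compound 4 (within the scatter) in this assay. Among the compounds shown here, the earlier step changed only one ring for another, so this is the first reading on the chain itself, and it shows that one added methyl at this place, three bonds along the chain from an aromatic nitrogen, leaves the maximal response of this pair within the usual scatter. Nothing measured here explains the size of this step.

A single added carbon does not show how far the chain can be changed: a longer chain such as hexyl, a branched chain such as isobutyl, or a chain ending in an amine or a carboxylic acid could behave differently. On these data alone, whether any of these would shift the response beyond the scatter remains open.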